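The source may report more compounds than this note shows. Statements on the series, on what has been measured and on what is new or still open speak of the compounds shown alone.

Measured so far in a functional assay on MCF7 cells (Homo sapiens) for inhibition, read by MTT assay, with a stated time of 72 h; a lower number here means a stronger inhibitor, a higher number a weaker inhibitor: compound 1 `CN(C(=O)NC(=O)c1ccc(Cl)cc1Cl)c1nc(C(F)(F)F)c(C(=O)N/N=C/c2ccc(C(F)(F)F)cc2)s1`, 8.42 ug/mL; compound 2 `CN(C(=O)NC(=O)c1c(F)cccc1F)c1nc(C(F)(F)F)c(C(=O)N/N=C/c2cccc(C(F)(F)F)c2)s1`, 21.8 ug/mL; compound 3 `Cc1nc(N(C)C(=O)NC(=O)c2c(F)cccc2F)sc1C(=O)N/N=C/c1cccc(C(F)(F)F)c1`, 28.2 ug/mL.

Compound 1 has the lowest number of the three, and its gaps to compound 2 and to compound 3 lie beyond the scatter. Compound 2 and compound 3 differ in one place, (methyl in place of trifluoromethyl on an aromatic carbon), and this gave a 1.3-fold higher number from compound 2 to compound 3 (0.11 log units; within the scatter). Compound 1 and compound 2 differ in more than one place; the difference between the two cores is not broken down here.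

Compound 4 `Cc1nc(N(C)C(=O)NC(=O)c2ccc(Cl)cc2Cl)sc1C(=O)N/N=C/c1ccc(C(F)(F)F)cc1` has not yet been measured in this assay. It differs from compound 1 by the same change, (methyl in place of trifluoromethyl on an aromatic carbon). The expectation rests on the step of a 1.3-fold higher number from compound 2 to compound 3 (0.11 log units; within the scatter), which stayed within the scatter. The expected step is a 1.3-fold higher number from compound 1 to compound 4 (0.12 log units; within the scatter). Compound 4 is therefore estimated at 11 ug/mL, between 5.5 ug/mL and 25 ug/mL.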

Compound 4, half-maximal inhibitory concentration: 24.5 ug/mL
Compound 4: middle estimate off by 2.2-fold (0.35 log units), on the low side; the measured number falls inside the stated range.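

In this assay, methyl in place of trifluoromethyl on the core of compound 1 gave a 2.9-fold higher number from compound 1 to compound 4 (0.46 log units; beyond the scatter). Set beside the step on the other core, this one does not differ from it by more than the scatter of two such steps allows: the same change on two cores in this assay, a 1.3-fold higher number (0.11 log units; within the scatter) from compound 2 to compound 3 and a 2.9-fold higher number (0.46 log units; beyond the scatter) from compound 1 to compound 4, 2.2-fold (0.35 log units) apart, within the scatter of two such steps. The change can thus be read as carrying from one core to the other, but two pairs fix no single size for it and do not show that it would hold on a further core.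

The compounds shown leave open how an amine or a longer chain in place of the trifluoromethyl would read. They also leave open whether the two steps would stay alike with other groups at the aromatic ends of the molecule.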